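The compounds below may be only part of what the source reports. "The series", "measured", "known", "first", "only" and "open" are said of these compounds alone.

Of the compounds shown here, three have so far been measured in an assay on HeLa cells for binding affinity to Vasopressin V2 receptor (Homo sapiens); a lower number here means a stronger inhibitor, a higher number a weaker inhibitor. Compound 1 `CCN(CC)c1ccc(C(=O)N2CCCCc3ccccc32)c(Cl)c1` gives 19 nM in this assay. Compound 2 `CN(C)c1ccc(C(=O)N2CCCCc3cc(Cl)ccc32)c(Cl)c1` gives 13 nM, which lies within the scatter of compound 1. Compound 3 `O=C(c1ccc(-n2cccc2)cc1)N1CCCCc2ccccc21` gives 320 nM, a number far above the other two and beyond the scatter. Compound 1 thus sits second highest of the three numbers; its nearest neighbour is compound 2 and its furthest is compound 3. Compound 4 `Cc1ccn(-c2ccc(C(=O)N3CCCCc4ccccc43)c(Cl)c2)n1` has not yet been measured. It differs from compound 1 by 3-methyl-1H-pyrazol-1-yl in place of diethylamino on an aromatic carbon. Among the measured compounds shown here, no measured pair shows this exchange on its own, so the expected size of the step rests on what the three numbers show. Of the measured compounds, the one whose structure comes closest to compound 4 is compound 3, and compound 3 gives 320 nM, a value that lies well beyond the scatter from compound 1, which suggests that a ring of this kind at this place goes with a weaker number. Compound 4 is therefore expected to show a step of a 3.4-fold higher number from compound 1 to compound 4 (0.53 log units; beyond the scatter) upward beyond the scatter, with an estimated value of 65 nM, ranging from 15 nM to 280 nM.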

Compound 4, half-maximal inhibitory concentration: 13 nM
The estimate for compound 4 lay 5.0-fold (0.70 log units) above the measured number; the whole stated range lies above it.
By their numbers in this assay, from the lowest: compounds 2, 4 and 1 (each within the scatter of the next); then compound 3.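

In this assay the exchange of diethylamino, which has no ring, for 3-methyl-1H-pyrazol-1-yl gives a 1.5-fold lower number from compound 1 to compound 4 (0.16 log units; within the scatter) and so shows that this place, para to a large group and meta to a chloro group, can carry a five-membered aromatic ring with 2 hetero atoms while the number stays within the scatter of compound 1. Compound 3 also carries a five-membered aromatic ring here, but it differs from compound 4 in more than one place, so this result does not explain its number. Nothing on hand accounts for why the two groups give numbers within the scatter of each other.

Going by these compounds, it remains open what the methyl group on the ring contributes, and whether an unsubstituted pyrazole or an imidazole would read the same. A morpholine or a carboxylic acid at this place is also left open.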